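The source may hold more compounds than are shown below. What is called first, only, known or untested is meant among the compounds shown, and "the series" means these compounds.

The measured compounds are:

compound 1, `CNC(=O)N1CCCc2ccc(NC(=O)c3cccc(-c4ccn(C)n4)c3)cc21`, with 70.5% in a functional assay on MV4-11 cells (Homo sapiens) for antiproliferative activity, with a stated time of 6 days, tested at 1.56 uM; a lower number here means a weaker effect, a higher number a stronger effect of the compound at the concentration tested
compound 2, `CNC(=O)N1CCCc2ccc(NC(=O)c3ccc(-c4ccn(C)n4)cc3)cc21`, with 72.2%
compound 3, `CNC(=O)N1CCCc2ccc(NC(=O)c3ccc(-c4ccncc4)cc3)cc21`, with 37.6%

Among these three numbers compound 1 holds the second highest place. Its nearest neighbour is compound 2, whose value lies within the scatter of compound 1, so the two cannot be ranked against each other. The furthest is compound 3, which stands well below compound 1, beyond the scatter. Going by the values given here, the only measured step between compounds differing in one place is a number 34.6 percentage points lower from compound 2 to compound 3 (beyond the scatter); there the 1-methyl-1H-pyrazol-3-yl ring gave way to a pyridine ring and the value fell sharply.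

Compound 4, `CNC(=O)N1CCCc2ccc(NC(=O)c3cccc(-c4cnn(C(C)=O)c4)c3)cc21`, is unmeasured. It differs from compound 1 as follows: 1-acetyl-1H-pyrazol-4-yl in place of 1-methyl-1H-pyrazol-3-yl on an aromatic carbon. Among the compounds with values here, no measured step concerns an acetyl-bearing pyrazole, so the step from compound 2 to compound 3 is the only guide, and it only shows that exchanging the 1-methyl-1H-pyrazol-3-yl ring for a different aromatic ring produced a large fall. A drop of similar or somewhat smaller size is therefore expected, with wide uncertainty. Compound 4 is estimated to give 50%, in the range 20% to 75%. The expected step is a number 20.5 percentage points lower from compound 1 to compound 4 (beyond the scatter).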

Compound 4, a percentage reported as inhibition, at one concentration (the size of the read-out at that concentration, not a potency): 33.6%
The estimate for compound 4 lay 16.4 percentage points above the measured number; measured number inside the range.
By their numbers in this assay, from the lowest: compounds 4 and 3 (each within the scatter of the next); then compounds 1 and 2 (each within the scatter of the next).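

At this place, on an aromatic carbon of a six-membered aromatic ring of carbon only, meta to a large group, putting 1-acetyl-1H-pyrazol-4-yl in place of 1-methyl-1H-pyrazol-3-yl gives in this assay a number 36.9 percentage points lower from compound 1 to compound 4 (beyond the scatter). The earlier compounds shown here showed a large fall only on going to a pyridin-4-yl ring, whereas here the entering group is still a five-membered aromatic ring with 2 hetero atoms, so keeping that kind of ring did not by itself hold the value in this pair. Nothing available explains this fall.

The step changes two things at once, the point of attachment on the pyrazole and the group on its nitrogen, and the compounds shown do not tell which of the two accounts for the fall, a question that 1-methyl-1H-pyrazol-4-yl at this same place could help to separate. Also open, on these data alone, is how this position responds to a pyrazole carrying an amine or a longer chain on its nitrogen, or to a pyrazole with no group on that nitrogen at all.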